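Extending the Methyl to an Allyl Group

The compounds below may be only part of what the source reports. "The series", "measured", "known", "first", "only" and "open" are said of these compounds alone.

Compound 1 `Cc1c(C#Cc2ccc(CCC(=O)O)cc2)ccnc1Cl` stands at the top of the three numbers measured in an in vitro functional assay on 1321-N1 cells for agonist activity at Free fatty acid receptor 1 (Homo sapiens), read by fluorescence, spectrophotometry and calcium flux (on this read-out lower numbers stand for an effect already at smaller amounts and higher numbers for an effect only at larger amounts of compound), where compound 1 gives 135 nM. Compound 3 `Cc1c(C#Cc2ccc(CCC(=O)O)cc2)ccnc1F` gives 120 nM; the step of a 1.1-fold lower number from compound 1 to compound 3 (0.05 log units; within the scatter) brings fluoro in place of chloro on an aromatic carbon and stays within the scatter. Among the measured compounds shown here, compound 2 `Cc1c(C#Cc2ccc(CCC(=O)O)cc2)cc(Cl)nc1Cl` gives 43.7 nM; the step of a 3.1-fold lower number from compound 1 to compound 2 (0.49 log units; beyond the scatter) brings chloro in place of hydrogen on an aromatic carbon and is the only change among the measured compounds that moves the number beyond the scatter.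

Compound 4 `C=CCc1c(C#Cc2ccc(CCC(=O)O)cc2)ccnc1Cl` differs from compound 1 by vinyl in place of hydrogen on a saturated chain carbon bound to an aromatic carbon; cut one bond further out, the methyl group becomes an allyl group. Neither measured step bears directly on this change: both alter substituents on aromatic carbons of the shared core, whereas here a vinyl group is attached to a saturated chain carbon. The steps already seen, from compound 1 to compound 3 and from compound 1 to compound 2, show that single changes of this size on the core have so far produced at most a modest shift. For the measured compounds named here, with no direct precedent, the step of a 1.1-fold higher number from compound 1 to compound 4 (0.05 log units; within the scatter) is expected to stay within the scatter. Compound 4 is therefore estimated at 150 nM, with a range from 50 nM to 450 nM.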

Compound 4, half-maximal effective concentration: 316 nM
The estimate for compound 4 lay 2.1-fold (0.32 log units) below the measured number; the range from low to high includes it.
By their numbers in this assay, from the lowest: compound 2; then compounds 3 and 1 (each within the scatter of the next); then compound 4.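

In this assay, the change from methyl to allyl gives a 2.3-fold higher number from compound 1 to compound 4 (0.37 log units; beyond the scatter), so added atoms at this saturated chain carbon bound to an aromatic carbon do alter the number, although the step remains modest. Among the compounds shown here, the earlier compounds showed nothing about this place, as both of their changes sit on aromatic carbons, and their only step beyond the scatter, a 3.1-fold lower number from compound 1 to compound 2 (0.49 log units; beyond the scatter), runs towards a lower number, whereas the allyl group gives the first step beyond the scatter towards a higher one. Nothing measured here explains this rise, so its cause remains unknown.

The compounds shown leave open whether the higher number goes with the greater length of the chain or with its double bond, a question that a propyl group in the same place would help to separate. They also leave open how an ethyl group or a chain ending in an amine would behave here, and whether the added chloro of compound 2 would still bring a lower number alongside the allyl group.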